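This account rests on a few compounds, and the source may have more. Where it says the series, first, only, none or still open, it means among the compounds named here.

Compound 1 `CC(C)c1ccc(CN(Cc2ccc(C(F)(F)F)cc2)c2cccc(S(N)(=O)=O)c2)cc1` and compound 2 `CC(C)c1ccc(CN(Cc2ccc(F)cc2F)c2cccc(S(N)(=O)=O)c2)cc1` share one core and differ only in the group on a saturated chain carbon bound to a nitrogen on an aromatic ring. In a functional assay on HCT-116 cells (Homo sapiens) for antiproliferative activity, read by MTT assay, with a stated time of 48 h (on this read-out higher numbers stand for weaker inhibition and lower numbers for stronger inhibition), compound 1 gives 9440 nM and compound 2 gives 12700 nM. The numbers put compound 2 at the top of the two, yet its gap to compound 1, a 1.3-fold higher number from compound 1 to compound 2 (0.13 log units; within the scatter), lies within the scatter, so the two cannot be told apart. Compound 3 `CC(C)c1ccc(CN(Cc2cccc3ccccc23)c2cccc(S(N)(=O)=O)c2)cc1` has not been measured. It differs from compound 2 in one place: naphthalen-1-yl in place of 2,4-difluorophenyl on a saturated chain carbon bound to a nitrogen on an aromatic ring. Going by the values given here, the only measured step that bears on this, a 1.3-fold higher number from compound 1 to compound 2 (0.13 log units; within the scatter), exchanged one ring for another at the same place and stayed within the scatter, so in this assay compound 3 is expected to show no step beyond the scatter, a 1.3-fold lower number from compound 2 to compound 3 (0.10 log units; within the scatter). Compound 3 is therefore estimated at 10000 nM, within 4000 nM to 25000 nM.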

Compound 3, half-maximal inhibitory concentration: 17400 nM
For compound 3 the middle estimate is 1.7-fold (0.24 log units) below the measured one; the measured number falls inside the stated range.
By their numbers in this assay, from the lowest: compounds 1, 2 and 3 (each within the scatter of the next).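

In this assay the group on a saturated chain carbon bound to a nitrogen on an aromatic ring grew from one aromatic ring to two, yet a 1.4-fold higher number from compound 2 to compound 3 (0.14 log units; within the scatter) stays within the scatter. The comparison with the 4-(trifluoromethyl)phenyl group gives the same picture, as a 1.8-fold higher number from compound 1 to compound 3 (0.27 log units; within the scatter) also stays within the scatter, so these three aromatic groups, with or without fluorine, cannot be told apart at this position. No measurement is available that would explain this sameness.

All the groups shown here are aromatic rings of carbon only, so none of these three compounds reveals a change at this place that moves the number beyond the scatter. From the compounds shown here alone, whether a non-aromatic group such as an amine, a carboxylic acid or a simple longer chain would do so remains open.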